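This account rests on a few compounds, and the source may have more. Where it says the series, first, only, none or still open, it means among the compounds named here.

Compound 1, `Cc1ccccc1NC(=O)CCC(=O)OCCCCCCSc1ccc([N+](=O)[O-])c2nonc12`: 4020 nM
Compound 2, `COc1ccccc1NC(=O)CCC(=O)OCCCCCCSc1ccc([N+](=O)[O-])c2nonc12`: 2850 nM
Compound 3, `O=C(CCC(=O)OCCCCCCSc1ccc([N+](=O)[O-])c2nonc12)Nc1cccc(Cl)c1`: 1920 nM

These three compounds were tested in a functional assay on HOS cells (Homo sapiens) for inhibition, read by MTT assay, with a stated time of 72 h; a lower number here means a stronger inhibitor, a higher number a weaker inhibitor. Compound 3 has the lowest number of the three. Its step from compound 2 is a 1.5-fold lower number from compound 2 to compound 3 (0.17 log units; within the scatter), and its step from compound 1 is a 2.1-fold lower number from compound 1 to compound 3 (0.32 log units; beyond the scatter). Between the other two the step is a 1.4-fold lower number from compound 1 to compound 2 (0.15 log units; within the scatter). All three share the same core and differ only in the group on the amide-type nitrogen, and in every case that group is a substituted phenyl.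

Compound 4, `CCN(CC)CCCNC(=O)CCC(=O)OCCCCCCSc1ccc([N+](=O)[O-])c2nonc12`, changes the nature of that group: 3-(diethylamino)propyl in place of 3-chlorophenyl on an amide-type nitrogen. For the measured compounds named here, none of the three measured steps bears directly on this change, since each of them exchanged one aromatic group for another, and no compound here carries a non-aromatic group on the amide-type nitrogen. The direction of the step to compound 4 is therefore not anchored by the data, and the expected step of a 1.6-fold higher number from compound 3 to compound 4 (0.19 log units; within the scatter) is set close to no change with a wide margin. For compound 4 the estimate in this assay is 3000 nM, with an expected range from 800 nM to 12000 nM.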

Compound 4, half-maximal inhibitory concentration: 9060 nM
Compound 4: middle estimate off by 3.0-fold (0.48 log units), on the low side, and the stated range covers the measured number.
By their numbers in this assay, from the lowest: compounds 3, 2 and 1 (each within the scatter of the next, the first and the last beyond it); then compound 4.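

In this assay the step away from the aromatic groups is a 4.7-fold higher number from compound 3 to compound 4 (0.67 log units; beyond the scatter) and a 3.2-fold higher number from compound 2 to compound 4 (0.50 log units; beyond the scatter) and also a 2.3-fold higher number from compound 1 to compound 4 (0.35 log units; beyond the scatter) in each comparison. For the compounds shown here, compound 4, the only one here with no ring on the amide-type nitrogen, thus stands as the weakest of the four, which shows that this position tolerates exchange among the three substituted phenyl groups better than a change to 3-(diethylamino)propyl. No measurement shown here accounts for this difference.

The compounds shown do not separate the loss of the aromatic ring from the entry of the diethylamino nitrogen. A plain hexyl chain on the amide-type nitrogen, or a 3-(diethylamino)phenyl group, would be needed to tell these two apart.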